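This account rests on a few compounds, and the source may have more. Where it says the series, first, only, none or still open, it means among the compounds named here.

In a functional assay on HepG2 cells (Homo sapiens) for cytotoxicity, read by MTT assay (on this read-out lower numbers stand for stronger inhibition and higher numbers for weaker inhibition), compound 1 (`COc1ccc(/C=C/C(=O)c2ccc(OC)c3c2OC(C)(C)C=C3)cc1OCCCN(C)C`) gives 5550 nM and compound 2 (`COc1cccc(C(=O)Oc2cc(/C=C/C(=O)c3ccc(OC)c4c3OC(C)(C)C=C4)ccc2OC)c1`) gives 870 nM as the lower of the two numbers. Compound 3 (`COc1ccc(/C=C/C(=O)c2ccc(OC)c3c2OC(C)(C)C=C3)cc1OS(=O)(=O)Cc1ccccc1`) has benzylsulfonyl in place of (3-methoxyphenyl)carbonyl on an oxygen on an aromatic ring, a swap that counts as benzylsulfonyl in place of (3-methoxyphenyl)carbonyl on an oxygen on an aromatic ring in full. Going by the values given here, the one measured step at this oxygen, a 6.4-fold lower number from compound 1 to compound 2 (0.80 log units; beyond the scatter) for a different swap, is modest and brought in the group now leaving. Both groups hold a six-membered aromatic ring of carbon only, so only a small rise, none beyond the scatter, is expected in this assay here. The expected size is a 1.4-fold higher number from compound 2 to compound 3 (0.14 log units; within the scatter) by this estimate. Compound 3 is estimated at 1200 nM with an expected range of 400 nM to 3600 nM for its measurement.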

Compound 3, half-maximal inhibitory concentration: > 10000 nM
Compound 3 gave a limit, no number; the forecaster's own chance of this, stated with the estimate: 5%; middle value at least 8.3-fold (0.92 log units) away from the limit.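

Compound 3 reads > 10000 nM in this assay, which is a limit and not a number. The group on this oxygen can therefore matter greatly even at the same count of heavy atoms and with one six-membered aromatic ring of carbon only on each side: benzylsulfonyl in place of (3-methoxyphenyl)carbonyl gives an at least 11-fold higher number from compound 2 to compound 3 (1.06 log units; beyond the scatter). Set against 3-(dimethylamino)propyl, benzylsulfonyl gives an at least 1.8-fold higher number from compound 1 to compound 3 (0.25 log units; that floor lies within the scatter), so that floor alone does not separate these two groups.

As far as these compounds go, the true value of compound 3 stays open, as does whether the sulfonyl link or the benzyl part accounts for the step. A phenylsulfonyl group on this oxygen would help separate the two.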